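From an Unreadable Limit to a Larger Side Chain

The source may report more compounds than this note shows. Statements on the series, on what has been measured and on what is new or still open speak of the compounds shown alone.

Compound 2 `CC1(C)CC(=O)C=C(Nc2ccc(Br)cc2)C1` is the analogue of compound 1 `CC1(C)CC(=O)C=C(Nc2ccc(Cl)cc2)C1` with bromo in place of chloro on an aromatic carbon. In a functional assay on cells (blood, Homo sapiens) for inhibition, read by chemiluminescence, with a stated time of 30 min (on this read-out higher numbers stand for weaker inhibition and lower numbers for stronger inhibition), compound 1 gives only > 100 ug/mL, a limit of the assay rather than a number. In this assay compound 2 likewise gives > 100 ug/mL, again a limit. The step that the two limits leave unreadable from compound 1 to compound 2 cannot be read, because of the limit of > 100 ug/mL in this assay, at which 2 of the 2 values shown sit. Compound 3 `CC1(C)CC(=O)C(C(=S)SCCO)=C(Nc2ccc(Br)cc2)C1` differs from compound 2 by a group of 6 heavy atoms (3 carbon, 1 oxygen, 2 sulfur; no ring) in place of a hydrogen atom, on a double-bonded ring carbon. Within the data shown here, no measured step bears on a change of this kind, so no direction can be drawn. Compound 3 is therefore estimated at 100 ug/mL, spanning 10 ug/mL to 300 ug/mL. That amounts to an expected step of a number no higher from compound 2 to compound 3 (the limit leaves the size open).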

Compound 3, half-maximal inhibitory concentration: > 100 ug/mL
Compound 3 was reported as a limit; the forecaster's own chance of this, stated with the estimate: 60%; the middle value lies on the limit itself.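

In this assay, among these compounds, compound 3 also gives > 100 ug/mL as a limit of the assay, so no step from compound 2 to compound 3 can be read. The compounds shown leave open how strongly any of them inhibits, and whether the larger side chain changes that at all.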